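Biaryl urea series: replacing the acrylamide arm of compound 3

The source may hold more compounds than are shown below. What is called first, only, known or untested is meant among the compounds shown, and "the series" means these compounds.

Going by the values given here, compound 3 `O=C(/C=C/c1ccc(NC(=O)Nc2ccc(Cl)c(C(F)(F)F)c2)cc1)NC1CCC1` holds the only true number in the set: in a functional assay on A-375 cells (Homo sapiens) for inhibition, read by MTT assay, with a stated time of 120 h (on this read-out higher numbers stand for weaker inhibition and lower numbers for stronger inhibition), compound 3 gives 15400 nM. Compound 1 `CNC(=O)/C=C(\C)c1ccc(NC(=O)Nc2ccc(Cl)c(C(F)(F)F)c2)cc1` returns only a limit, > 50000 nM, in this assay. Compound 2 `O=C(CCc1ccc(NC(=O)Nc2ccc(Cl)c(C(F)(F)F)c2)cc1)NC1CCC1` likewise sits at a limit, > 50000 nM, in this assay. Both limits are the same line, (the limit of > 50000 nM in this assay, at which 2 of the 3 values shown sit). The steps of an at least 3.2-fold lower number from compound 1 to compound 3 (0.51 log units; beyond the scatter) and an at least 3.2-fold lower number from compound 2 to compound 3 (0.51 log units; beyond the scatter) favour compound 3, and only their floor is readable. Compound 4 `CNC(=O)c1cccc(-c2ccc(NC(=O)Nc3ccc(Cl)c(C(F)(F)F)c3)cc2)c1` differs from compound 3 by 3-(methylcarbamoyl)phenyl in place of 2-(cyclobutylcarbamoyl)ethenyl on an aromatic carbon. Among the compounds with values here, no measured step changes the arm in this way, and the steps into compound 3 set only a lower bound. Compound 4 is expected to land near compound 3, with the estimated step of a 1.5-fold lower number from compound 3 to compound 4 (0.19 log units; within the scatter) within the scatter. The estimate for compound 4 is 10000 nM, ranging from 2000 nM to 50000 nM.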

Compound 4, half-maximal inhibitory concentration: 46500 nM
Estimate against measurement, compound 4: 4.7-fold (0.67 log units) below, within the range that was stated.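

At this aromatic carbon, para to a large group, 3-(methylcarbamoyl)phenyl in place of 2-(cyclobutylcarbamoyl)ethenyl gives a 3.0-fold higher number from compound 3 to compound 4 (0.48 log units; beyond the scatter) in this assay. Going by these compounds alone, this is the first step with true numbers at both ends, so its size can be read rather than only a floor. Against the other two compounds only floors remain, an at least 1.0-fold lower number from compound 2 to compound 4 (0.03 log units; that floor lies within the scatter) and an at least 1.0-fold lower number from compound 1 to compound 4 (0.03 log units; that floor lies within the scatter), and neither separates compound 4 from them: the limit of > 50000 nM in this assay, at which 2 of the 4 values shown sit.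

The step swaps the ethenyl linker for a phenyl ring and the cyclobutyl amide for a methyl amide together, and the compounds shown do not separate these two changes. On these data alone, how a 3-(cyclobutylcarbamoyl)phenyl arm, or an amine in place of the amide, would read stays open.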